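Acetamido in Place of Amidine on the Shared Core

The compounds below may be only part of what the source reports. "The series", "measured", "known", "first", "only" and "open" are said of these compounds alone.

Compound 2 `C[C@H]1CN(c2ncc(C(=N)N)cc2Cl)CCN1C1CCN(Cc2ccc(Cl)cc2)CC1` gives 80 nM in a functional assay for antagonist activity at C-X-C chemokine receptor type 3 (Homo sapiens) (on this read-out higher numbers stand for weaker inhibition and lower numbers for stronger inhibition), the higher of the two numbers in hand; compound 1 `CNC(=O)c1cnc(N2CCN(C3CCN(Cc4ccc(Cl)cc4)CC3)[C@@H](C)C2)c(Cl)c1` gives 32 nM. Compound 3 `CC(=O)Nc1cnc(N2CCN(C3CCN(Cc4ccc(Cl)cc4)CC3)[C@@H](C)C2)c(Cl)c1` carries a group of 4 heavy atoms (2 carbon, 1 nitrogen, 1 oxygen; no ring) in place of a group of 3 heavy atoms (1 carbon, 2 nitrogen; no ring), on an aromatic carbon. Within the data shown here, the only measured step that bears on this change is a 2.5-fold higher number from compound 1 to compound 2 (0.40 log units; beyond the scatter), in which a group of the same kind and make-up as the acetamido left and the amidine entered. Reversing that swap in kind, compound 3 is expected to show a 2.0-fold lower number from compound 2 to compound 3 (0.30 log units; within the scatter) in this assay. The estimate for compound 3 is 40 nM, with a range of 15 nM to 120 nM.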

Compound 3, half-maximal inhibitory concentration: 8 nM
Compound 3: the middle estimate sits 5.0-fold (0.70 log units) above what was measured, outside the stated range (below it).
By their numbers in this assay, from the lowest: compound 3; then compound 1; then compound 2.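

In (this assay), acetamido gives the lowest number of the three compounds at this position, with (a 10-fold lower number from compound 2 to compound 3 (1.00 log units; beyond the scatter)) and (a 4.0-fold lower number from compound 1 to compound 3 (0.60 log units; beyond the scatter)). The earlier pair showed only that this position separates methylcarbamoyl from the amidine group; compound 3 shows that it also separates acetamido from methylcarbamoyl, two groups of the same atom make-up. No measurement at hand accounts for this difference.

On these data alone, whether a longer chain, such as propanamido, or a plain amine would go lower or higher here remains open. Also open, as far as these compounds go, is whether acetamido would keep its lead without the chloro group.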